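Replacing 3-fluorophenyl with pyridin-3-yl in compound 1

The source may hold more compounds than are shown below. What is called first, only, known or untested is meant among the compounds shown, and "the series" means these compounds.

compound 1 `Nc1ccccc1NC(=O)c1ccc(NC(=S)NCc2cccc(F)c2)cc1` gives 2900 nM
compound 2 `Nc1ccccc1NC(=O)c1ccc(CNC(=O)c2cc3cccnc3[nH]2)cc1` gives 6100 nM

In a functional assay on HepG2 cells (Homo sapiens) for cytotoxicity, read by MTT assay, with a stated time of 72 h (a higher number here means a weaker inhibitor, a lower number a stronger inhibitor), compound 1 holds the lower of the two numbers, and the gap up to compound 2 lies just beyond the usual scatter of repeated measurements.

Compound 3 `Nc1ccccc1NC(=O)c1ccc(NC(=S)NCc2cccnc2)cc1` has not yet been measured. It keeps the core of compound 1 but carries pyridin-3-yl in place of 3-fluorophenyl on a saturated chain carbon bound to an amide-type nitrogen. Among the compounds with values here, no measured pair here shows what such an exchange does, so the expectation rests on thin ground. Compound 1 and compound 2 differ widely in structure, yet their values are not far apart. A large change from a single ring exchange therefore seems unlikely, and in this assay a small move towards a higher number is expected, possibly no larger than the scatter. The estimated step of a 1.6-fold higher number from compound 1 to compound 3 (0.19 log units; within the scatter) is modest and carries wide uncertainty. Compound 3 is estimated at 4500 nM (expected range 1500 nM to 13000 nM).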

Compound 3, half-maximal inhibitory concentration: 4200 nM
Beside the measured number, compound 3's estimate is 1.1-fold (0.03 log units) above it; the range from low to high includes it.
By their numbers in this assay, from the lowest: compounds 1, 3 and 2 (each within the scatter of the next, the first and the last beyond it).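

This is the first step shown that alters one place only: with pyridin-3-yl in place of 3-fluorophenyl on a saturated chain carbon bound to an amide-type nitrogen, this assay gives a 1.4-fold higher number from compound 1 to compound 3 (0.16 log units; within the scatter). At this position, a six-membered aromatic ring of carbon only can thus give way to one with a single hetero atom and a hydrogen-bond acceptor, and compound 3 still cannot be told apart from compound 1 in this read-out. No measurement offered here bears on the reason for this result.

What the compounds shown leave open is how far this position stays so undemanding, since a single ring exchange in a single assay cannot settle that: plain phenyl would separate the part played by the fluorine from that of the ring nitrogen, while an amine or a carboxylic acid on the ring, or a longer chain at this place, would test it with more distant groups. Compound 2 differs from compound 1 and compound 3 in more than one place, so it adds nothing on this exchange.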